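From ethyl to phenyl: what compound 4 may do

The source may hold more compounds than are shown below. What is called first, only, known or untested is meant among the compounds shown, and "the series" means these compounds.

Values measured in an ADME assay on J774 cells (Mus musculus) for antiproliferative activity, with a stated time of 72 h; a higher number here means that more compound is needed for the effect, a lower number that less compound is needed
compound 1 (`CCCCc1cc2c(=O)cc(C)[nH]c2cc1OCCOc1ccccc1`) gives 28000 nM
compound 2 (`CCCCc1cc2c(=O)c(CC)c(C)[nH]c2cc1OCCOc1ccccc1`) gives 1000 nM
compound 3 (`CCc1c(C)[nH]c2cc(OCCOc3ccccc3)c(Cl)cc2c1=O`) gives > 28000 nM (a limit of the assay, not a number)

Of the two values that are true numbers, the lower belongs to compound 2 (1000 nM). Compound 1 stands well above it, as the step (a 28-fold lower number from compound 1 to compound 2 (1.45 log units; beyond the scatter)) shows.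

Compound 4 (`CCCCc1cc2c(=O)c(-c3ccccc3)c(C)[nH]c2cc1OCCOc1ccccc1`) differs from compound 2 by phenyl in place of ethyl on an aromatic carbon. The closest guide is the step at that same carbon, ethyl in place of hydrogen (a 28-fold lower number from compound 1 to compound 2 (1.45 log units; beyond the scatter)), which was large. The other step, chloro in place of butyl (an at least 28-fold higher number from compound 2 to compound 3 (1.44 log units; beyond the scatter)), was also large, but it lies at another place and bears on this change only indirectly. For the measured compounds named here, no measured step puts a ring at this carbon. Compound 4 keeps a carbon group there, as compound 2 does (1000 nM), and it is therefore expected to retain most of that low number in this assay, with a moderate move toward a higher number and a shift much smaller than either measured step. The estimated change is (a 2.5-fold higher number from compound 2 to compound 4 (0.40 log units; beyond the scatter)). Compound 4 is expected near 2500 nM, within an estimated range from 500 nM to 12000 nM, and the measurement is still to come.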

Compound 4, half-maximal effective concentration: 23000 nM
Compound 4: the middle estimate sits 9.2-fold (0.96 log units) below what was measured, outside the stated range (above it).
By their numbers in this assay, from the lowest: compound 2; then compounds 4 and 1 (each within the scatter of the next).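

For the compounds shown here, at this aromatic carbon, two atoms from the ring nitrogen, the earlier compounds showed only that ethyl in place of hydrogen lowers the number in this assay, whereas phenyl in place of ethyl gives a 23-fold higher number from compound 2 to compound 4 (1.36 log units; beyond the scatter) and so removes that gain almost entirely. Phenyl in place of hydrogen gives a 1.2-fold lower number from compound 1 to compound 4 (0.09 log units; within the scatter), which lies within the scatter, so among the groups shown the low number belongs to ethyl and not to just any carbon group at this place. What is shown here gives no reason why ethyl and phenyl differ so much.

On these data alone, with only ethyl and phenyl as carbon groups at this place, it stays open where along the way from one to the other the low number is lost, for instance with a propyl group or a longer chain, and whether an amine or a carboxylic acid there would behave differently. As far as these compounds go, it also stays open whether ethyl and phenyl would rank the same way with chloro in place of butyl on the shared core.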